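Replacing a Methyl with Hydrogen on Compound 3

A few compounds are considered here, and "the series" means these few. Any claim that something is new, unique, unknown or untested is made for them only; others in the source may bear on it.

In a functional assay on MCF7 cells (Homo sapiens) for cytotoxicity, read by MTT assay, with a stated time of 72 h (on this read-out higher numbers stand for weaker inhibition and lower numbers for stronger inhibition), compound 1 `COc1ccc(/C=N/NC(=O)Nc2cc3c(Nc4ccc(F)c(Cl)c4)ncnc3cc2O[C@H]2CCOC2)cc1` gives 27300 nM, compound 2 `COc1cc2ncnc(Nc3ccc(F)c(Cl)c3)c2cc1NC(=O)N/N=C/c1cccc(Cl)c1Cl` gives 28700 nM, and compound 3 `COc1ccc(/C=N/NC(=O)Nc2cc3c(Nc4ccc(F)c(Cl)c4)ncnc3cc2OC)cc1` gives 8140 nM, the lowest of the three numbers. Compound 4 `COc1cc2ncnc(Nc3ccc(F)c(Cl)c3)c2cc1NC(=O)N/N=C/c1ccc(O)cc1` carries hydrogen in place of methyl on an oxygen on an aromatic ring, so methoxy becomes hydroxy (hydrogen in place of methyl on an oxygen on an aromatic ring). The closest evidence is a 3.5-fold lower number from compound 2 to compound 3 (0.55 log units; beyond the scatter), which came with 4-methoxyphenyl replacing 2,3-dichlorophenyl. On a different oxygen, methyl replacing oxolan-3-yl gave a 3.4-fold lower number from compound 1 to compound 3 (0.53 log units; beyond the scatter). Both steps are modest, and neither tests hydroxy directly. A modest rise is therefore expected, namely a 1.5-fold higher number from compound 3 to compound 4 (0.17 log units; within the scatter). Compound 4 is estimated at 12000 nM, with an expected range of 5000 nM to 29000 nM.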

Compound 4, half-maximal inhibitory concentration: 28600 nM
The estimate for compound 4 lay 2.4-fold (0.38 log units) below the measured number, and the stated range covers the measured number.
By their numbers in this assay, from the lowest: compound 3; then compounds 1, 4 and 2 (each within the scatter of the next).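

In this assay, taking off the single methyl carbon gives a 3.5-fold higher number from compound 3 to compound 4 (0.55 log units; beyond the scatter) and so shows that the oxygen alone does not keep the lower number of compound 3. Swapping 2,3-dichlorophenyl for 4-hydroxyphenyl gives a 1.0-fold lower number from compound 2 to compound 4 (0.00 log units; within the scatter) and stays within the usual scatter, so the advantage seen with 4-methoxyphenyl depends on the methyl being present. The data shown offer no measured explanation for this. Still open, going by these compounds, is whether a longer chain on this oxygen, such as ethyl, would keep the lower number, and whether an amine in place of methoxy would do so.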